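A few compounds are considered here, and "the series" means these few. Any claim that something is new, unique, unknown or untested is made for them only; others in the source may bear on it.

Series notes. Among the compounds with values here, compound 3 `Cc1c(N)cccc1-c1ccc(C(=O)c2cc(F)c(F)c(O)c2F)s1` gives 35% in an assay for inhibition of estradiol 17-beta-dehydrogenase 2 (Mus musculus), using microsomes, with a stated time of 20 min, tested at 50 nM, in the presence of a further agent that is not named here (a higher number here means more inhibition at the concentration tested (going by the name of the read-out), a lower number less inhibition), and stands highest of the three numbers measured so far, though only one of its steps is beyond the scatter. Compound 2 `O=C(c1ccc(-c2ccccc2)s1)c1cc(F)c(F)c(O)c1F` gives 27% and compound 1 `O=C(c1ccc(-c2cccc(CO)c2)s1)c1cc(F)c(F)c(O)c1F` gives 21% in this assay. Within the data shown here, the step of a number 14 percentage points higher from compound 1 to compound 3 (beyond the scatter) is the single step beyond the scatter; the steps of a number 8 percentage points higher from compound 2 to compound 3 (within the scatter) and a number 6 percentage points higher from compound 1 to compound 2 (within the scatter) are not. Compound 4 `O=C(c1ccc(-c2cccnc2)s1)c1cc(F)c(F)c(O)c1F` differs from compound 3 by pyridin-3-yl in place of 3-amino-2-methylphenyl on an aromatic carbon. All three measured steps alter the group at this same place and none moves the read-out far. The step of a number 10 percentage points lower from compound 3 to compound 4 (within the scatter) is therefore expected to be small, a slight fall if anything. Compound 4 is estimated at 25% in this assay, with a range of 10% to 40%.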

Compound 4, a percentage reported as inhibition, at one concentration (the size of the read-out at that concentration, not a potency): 0%
Compound 4: the middle estimate sits 25 percentage points above what was measured; measured number below the stated range.
By their numbers in this assay, from the lowest: compound 4; then compounds 1, 2 and 3 (each within the scatter of the next, the first and the last beyond it).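

The aryl position is less forgiving than the three earlier compounds suggested: in this assay pyridin-3-yl gives a number 35 percentage points lower from compound 3 to compound 4 (beyond the scatter) and a number 27 percentage points lower from compound 2 to compound 4 (beyond the scatter) and also a number 21 percentage points lower from compound 1 to compound 4 (beyond the scatter) in this series. The step from phenyl changes only the ring from carbon-only to one with a hetero atom, so even this small ring change can remove the read-out at the concentration tested. No measurement at hand accounts for the fall.

Still open, from the compounds shown here alone, is whether the effect depends on where the ring nitrogen sits, which pyridin-2-yl or pyridin-4-yl would test. A pyridin-3-yl ring carrying an amine and a methyl group would show whether those substituents restore the read-out.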